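A few compounds are considered here, and "the series" means these few. Any claim that something is new, unique, unknown or untested is made for them only; others in the source may bear on it.

Working notes on the series, read in a functional assay on MT4 cells (Homo sapiens) for inhibition; a higher number here means a weaker inhibitor, a lower number a stronger inhibitor. Compound 1 `C=C1[C@@H](O)[C@H](n2cnc3c(O)ncnc32)O[C@@H]1CO` gives > 200000 nM, which is a limit and not a number. Compound 2 `C=C1[C@H](n2cnc3c(N)nc(N)nc32)O[C@H](CO)[C@H]1O` gives > 500000 nM, which is likewise a limit and not a number. Among the measured compounds shown here, compound 2 therefore has no numerical place: both readings so far are limits, and no step between measured compounds is available as a guide.

The next compound is compound 3 `C=C1[C@H](n2cnc3c(SC)nc(N)nc32)O[C@H](CO)[C@H]1O`, which carries methylsulfanyl in place of amino on an aromatic carbon, next to the ring nitrogen: methylsulfanyl in place of amino on an aromatic carbon. The second amino group of compound 2 remains in compound 3, meta to the changed position.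

The expectation starts from the limit of compound 2, > 500000 nM. No change beyond the scatter is expected, and the estimated change is an at least 1.4-fold lower number from compound 2 to compound 3 (0.15 log units; that floor lies within the scatter). Another reading that is only a limit is the likeliest outcome. For compound 3 the estimated value in this assay is 350000 nM, with an expected range from 80000 nM to 600000 nM.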

Compound 3, half-maximal inhibitory concentration: > 500000 nM
Compound 3: a limit, no number; the forecaster's own chance of this, stated with the estimate: 75%; middle value at least 1.4-fold (0.15 log units) from the limit.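

Compound 3 gives > 500000 nM, which is a limit and not a number. Compound 2 is also only a limit, so no step can be read between compound 2 and compound 3: the limit of > 500000 nM in this assay, at which 2 of the 3 values shown sit.

The compounds shown leave open whether methylsulfanyl in place of amino on an aromatic carbon changes inhibition at all.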